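Trifluoromethyl for Chloro on a Lyase Inhibitor Core

The compounds below may be only part of what the source reports. "The series", "measured", "known", "first", "only" and "open" are said of these compounds alone.

Compound 1: `C[C@@H]1CN(c2nnc(CCc3ccccc3)c3ccccc23)CCN1c1ccc(C#N)cn1` — 30000 nM
Compound 2: `C[C@@H]1CN(c2nnc(Cc3ccccc3)c3ccc(Cl)cc23)CCN1c1ccc(C#N)cn1` — 210 nM

Of the compounds shown here, two have been measured in an assay on Sf9 cells for inhibition of sphingosine-1-phosphate lyase 1 (Homo sapiens), with a stated time of 1 h; on this read-out higher numbers stand for weaker inhibition and lower numbers for stronger inhibition. Compound 1 gives 30000 nM in this assay, while compound 2 gives 210 nM. Compound 2 therefore stands with the lowest of the two numbers, and the gap to compound 1 is far beyond the usual scatter. Within the data shown here, the two structures differ in more than one place, so what they show is only that the two values lie far apart, not which change carries the difference.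

Compound 3, `C[C@@H]1CN(c2nnc(Cc3ccccc3)c3ccc(C(F)(F)F)cc23)CCN1c1ccc(C#N)cn1`, has not yet been measured. Relative to compound 2 it carries one change: trifluoromethyl in place of chloro on an aromatic carbon. Among the measured compounds shown here, no pair of measured compounds here differs by exactly this exchange, so there is no measured step to lean on. The expectation is that this exchange shifts the number in this assay little, if at all, leaving a step from compound 2 to compound 3 of a 1.2-fold higher number from compound 2 to compound 3 (0.09 log units; within the scatter), within the scatter. Compound 3 is estimated at 260 nM, with a range of 80 nM to 850 nM.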

Compound 3, half-maximal inhibitory concentration: 100 nM
Beside the measured number, compound 3's estimate is 2.6-fold (0.41 log units) above it, and the stated range covers the measured number.
By their numbers in this assay, from the lowest: compound 3; then compound 2; then compound 1.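

Among these compounds, this is the first pair that differs in one place only, so a single exchange can be read on its own: in this assay, putting trifluoromethyl in place of chloro on this aromatic carbon gives a 2.1-fold lower number from compound 2 to compound 3 (0.32 log units; beyond the scatter), a modest step. The position therefore accepts a group of 4 heavy atoms in place of a single chlorine without any loss of inhibition, and the number even moves slightly in the favourable direction. No measurement shown here offers an explanation for this step.

As far as these compounds go, what remains open is how this position responds to groups of a different kind, such as a methoxy group, an amine or a carboxylic acid, and whether the same exchange would give a similar step elsewhere on the shared core. Compound 1 carries no substituent at this position, but it also differs from compound 2 in a second place, so the compounds shown cannot tell how much the chloro or trifluoromethyl group itself contributes compared with plain hydrogen.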